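A Second Hydroxy Group on the Hydrazone Aryl Ring

A few compounds are considered here, and "the series" means these few. Any claim that something is new, unique, unknown or untested is made for them only; others in the source may bear on it.

Compound 3 `O=C(N/N=C/c1ccccc1O)c1cc(-c2ccc(Cl)cc2)nn1Cc1ccc(Cl)nc1` carries a 2-hydroxyphenyl group on a carbon with a double bond to nitrogen. Within the data shown here, in a functional assay on A549 cells (Homo sapiens) for antiproliferative activity, read by BrdU incorporation, with a stated time of 48 h (on this read-out higher numbers stand for weaker inhibition and lower numbers for stronger inhibition), compound 3 gives 300 nM, the lowest of the three numbers measured so far. Among the measured compounds shown here, compound 1 `O=C(N/N=C/c1ccc(F)cc1F)c1cc(-c2ccc(Cl)cc2)nn1Cc1ccc(Cl)nc1`, which carries a 2,4-difluorophenyl group at that carbon instead, gives 9050 nM in this assay, and the step of a 30-fold lower number from compound 1 to compound 3 (1.48 log units; beyond the scatter) is the only one-place comparison available. Compound 2 `N=C(NO)c1cc(-c2ccc(Cl)cc2)nn1Cc1ccc(Cl)nc1` differs from compound 3 in several places. In this assay, for the measured compounds named here, compound 2 gives 38300 nM, and the two values show only that compound 2 stands far higher.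

Compound 4 `O=C(N/N=C/c1cccc(O)c1O)c1cc(-c2ccc(Cl)cc2)nn1Cc1ccc(Cl)nc1` differs from compound 3 by hydroxy in place of hydrogen on an aromatic carbon; read one bond further out, a 2-hydroxyphenyl becomes a 2,3-dihydroxyphenyl. Going by the values given here, no measured step adds a hydroxy to a ring that already holds one. Among the compounds with values here, the only step that bears on the question is a 30-fold lower number from compound 1 to compound 3 (1.48 log units; beyond the scatter), which shows that the aryl ring on this carbon can move the number strongly, but it exchanged two fluorines for one hydroxy and says nothing about a second hydroxy. A modest change, possibly within the scatter and leaning toward a higher number, is therefore expected; the estimated step is a 1.5-fold higher number from compound 3 to compound 4 (0.18 log units; within the scatter). Compound 4 is expected to give about 450 nM in this assay, within an estimated range from 150 nM to 1400 nM.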

Compound 4, half-maximal inhibitory concentration: 700 nM
Estimate against measurement, compound 4: 1.6-fold (0.19 log units) below; the range from low to high includes it.
By their numbers in this assay, from the lowest: compound 3; then compound 4; then compound 1; then compound 2.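

The second hydroxy, placed ortho to the hydroxy group already on the ring, gives a 2.3-fold higher number from compound 3 to compound 4 (0.37 log units; beyond the scatter) in this assay, so this aromatic carbon is not a neutral site: the change is modest, but it goes beyond the scatter and moves away from the lowest number in the series. The 2,3-dihydroxyphenyl ring nevertheless keeps most of the advantage over the 2,4-difluorophenyl ring, with a 13-fold lower number from compound 1 to compound 4 (1.11 log units; beyond the scatter) still a large step, and so among the compounds shown, the two rings that carry a hydroxy both stand well below the fluorinated one. The data give no reason for the direction or the size of either step, and no supporting measurement bears on them.

From the compounds shown here alone, it remains open whether a methoxy, an amine or a fluorine on this same aromatic carbon would give a number closer to that of compound 3 or move further from it. Also open, going by these compounds, is whether the second hydroxy would have the same effect at another carbon of the ring, or whether the first hydroxy must remain in place for the number to stay low.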